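The source may hold more compounds than are shown below. What is called first, only, known or untested is meant among the compounds shown, and "the series" means these compounds.

Measured in an ADME assay on microsomes from liver (Rattus norvegicus) for metabolic stability; a higher number here means that the compound lasts longer, a lower number that the compound disappears faster:
Compound 1 `CC(C)C(/C=C1\NC(=O)NC1=O)c1ccc(-c2ccc3cccc(F)c3c2)[nH]c1=O`: 1.46 h
Compound 2 `CCc1cccc2ccc(-c3ccc(C(/C=C4\OC(=O)NC4=O)(CC)CC)c(=O)[nH]3)cc12`: 1.77 h

Compound 1 has one neighbour on this scale, compound 2, and the two values lie within the usual scatter of each other. Compound 3 `CC(C)C(CC1C(=O)NC(=O)N1C)c1ccc(-c2ccc3cccc(F)c3c2)[nH]c1=O` differs from compound 1 by one change: a group of 9 heavy atoms (5 carbon, 2 nitrogen, 2 oxygen; one five-membered non-aromatic ring with 2 hetero atoms) in place of a group of 8 heavy atoms (4 carbon, 2 nitrogen, 2 oxygen; one five-membered non-aromatic ring with 2 hetero atoms), on a saturated chain carbon bound to an aromatic carbon and a saturated chain carbon. The group entering is (3-methyl-2,5-dioxoimidazolidin-4-yl)methyl. Going by the values given here, no measured pair shows what such a change does, so no step beyond the scatter is expected in this assay, and no direction can be favoured with confidence. Compound 3 is estimated at 1.3 h, with an expected range of 0.6 h to 2.8 h.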

Compound 3, half-life: < 0.0667 h
Compound 3 ended at the assay's limit; the forecaster's own chance of this, stated with the estimate: 3%; middle value at least 19-fold (1.28 log units) from the limit.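

At this saturated chain carbon, the group carried matters greatly in this assay: putting (3-methyl-2,5-dioxoimidazolidin-4-yl)methyl in place of the earlier group gives an at least 21-fold lower number from compound 1 to compound 3 (1.34 log units; beyond the scatter). No earlier pair had shown any step at this position. The reading for compound 3 is a limit of the assay, not a number: the limit of < 0.0667 h in this assay, at which 1 of the 3 values shown sits.

On these data alone, the entering group differs in its methyl, its double bonds and its hydrogen-bond donors together, so which of these carries the step stays open. Also open, as far as these compounds go, is how a carboxylic acid or an amine would fare on this carbon.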